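The source may report more compounds than this note shows. Statements on the series, on what has been measured and on what is new or still open speak of the compounds shown alone.

Measured in a physicochemical assay for solubility, at pH 7.4; on this read-out higher numbers stand for higher solubility and lower numbers for lower solubility:
- compound 1 `NS(=O)(=O)c1ccc(SCCO)c(F)c1`: 6000 ug/mL
- compound 2 `NS(=O)(=O)c1ccc(SCCCO)c(F)c1`: 900 ug/mL
- compound 3 `NS(=O)(=O)c1ccc(SCCCCO)c(F)c1`: 1000 ug/mL

Compound 2 cannot be told apart from its nearest neighbour, with a 1.1-fold higher number from compound 2 to compound 3 (0.05 log units; within the scatter). Its furthest neighbour stands clearly apart, with a 6.7-fold lower number from compound 1 to compound 2 (0.82 log units; beyond the scatter). Compound 4 `COC(=O)c1cc(S(N)(=O)=O)ccc1SCCCO` alters the shared core rather than the chain: methoxycarbonyl in place of fluoro on an aromatic carbon. For the measured compounds named here, no measured step touches this aromatic carbon, so the chain steps guide size only. Two were modest and downward, a 6.7-fold lower number from compound 1 to compound 2 (0.82 log units; beyond the scatter) and a 6.0-fold lower number from compound 1 to compound 3 (0.78 log units; beyond the scatter). A modest fall in this assay is therefore expected, though the data cannot fix it firmly. The estimate amounts to a 2.3-fold lower number from compound 2 to compound 4 (0.35 log units; beyond the scatter). Compound 4 is estimated at 400 ug/mL, with an expected range of 120 ug/mL to 1200 ug/mL.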

Compound 4, solubility: 1300 ug/mL
Compound 4: the middle estimate sits 3.3-fold (0.51 log units) below what was measured; measured number outside the range, above it.
By their numbers in this assay, from the lowest: compounds 2, 3 and 4 (each within the scatter of the next); then compound 1.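

In this assay, methoxycarbonyl in place of fluoro on this aromatic carbon, ortho to a (3-hydroxypropyl)sulfanyl group, gives a 1.4-fold higher number from compound 2 to compound 4 (0.16 log units; within the scatter) for this change. The position therefore takes a group with more heavy atoms and two hydrogen-bond acceptors without a step that can be told from the scatter. The compounds shown offer no evidence on why this is so.

They leave open whether a carboxylic acid or an amine on this aromatic carbon would stay as close to compound 2, and whether methoxycarbonyl would give the same result on the chains of compound 1 and compound 3.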